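The source may hold more compounds than are shown below. What is called first, only, known or untested is meant among the compounds shown, and "the series" means these compounds.

Measured so far in a functional assay on Malme-3M cells (Homo sapiens) for cytotoxicity, read by MTT assay, with a stated time of 6 days (a lower number here means that less compound is needed, a higher number that more compound is needed for the effect), are two compounds:
Compound 1 `COC(=O)c1c(-c2ccc(OCc3ccccc3)cc2)oc2ccc(OC)cc2c1=O` | > 25 ug/mL
Compound 2 `COC(=O)c1c(-c2ccc(O)cc2)oc2ccccc2c1=O` | > 25 ug/mL

Compound 1 gives > 25 ug/mL as a limit, not a number. Compound 2 likewise gives > 25 ug/mL as a limit, so its standing is known only to that extent. The evidence so far is the limit of > 25 ug/mL in this assay, at which 2 of the 2 values shown sit, and nothing more. Compound 3 `COC(=O)c1c(-c2ccc(O)cc2)oc2ccc(OC)cc2c1=O` has methoxy in place of hydrogen on an aromatic carbon relative to compound 2, counted as methoxy in place of hydrogen on an aromatic carbon here. Going by the values given here, no measured step is available in this assay to guide the size of this change. The step of a number no higher from compound 2 to compound 3 (the limit leaves the size open) is expected to stay within the scatter, with no direction favoured. For compound 3 the estimate is 25 ug/mL with an expected range from 12 ug/mL to 50 ug/mL in this series.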

Compound 3, concentration for half-maximal effect: > 25 ug/mL
Compound 3: a limit, no number; the forecaster's own chance of this, stated with the estimate: 75%; the middle value sits exactly at the limit.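

Compound 3 gives > 25 ug/mL, a limit and not a number. The steps to it from compound 1 and compound 2 cannot be read. The compounds shown leave open what the methoxy or benzyl change does to the value.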